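Swapping a Small Group Between Two Ring Nitrogens

The source may report more compounds than this note shows. Statements on the series, on what has been measured and on what is new or still open speak of the compounds shown alone.

Compound 1 `CCCCOC(=O)NS(=O)(=O)c1ccc(CCC)cc1-c1ccc(Cn2c(C3CCCCC3)nc3ccccc32)cc1`: 130 nM
Compound 2 `CCCCOC(=O)NS(=O)(=O)c1ccc(CCC)cc1-c1ccc(Cn2c(C3CCC3)nc3ccccc32)cc1`: 12 nM
Compound 3 `CCCCOC(=O)NS(=O)(=O)c1ccc(CCC)cc1-c1ccc(Cn2c(C)nc3ccccc32)cc1`: 9.4 nM

All three share one core and differ only in the group on one aromatic carbon, each tested in an assay on membranes from HEK293 cells for displacement of a labelled ligand from Type-2 angiotensin II receptor (Homo sapiens), read by radioligand binding; on this read-out lower numbers stand for stronger inhibition and higher numbers for weaker inhibition. Compound 3 has the lowest of the three numbers, though a 1.3-fold lower number from compound 2 to compound 3 (0.11 log units; within the scatter), whereas a 14-fold lower number from compound 1 to compound 3 (1.14 log units; beyond the scatter). Compound 4 `CCCCOC(=O)NS(=O)(=O)c1ccc(CCC)cc1-c1ccc(Cn2c(C(F)(F)F)nc3ccccc32)cc1` carries trifluoromethyl in place of methyl on an aromatic carbon. Among the measured compounds shown here, two steps bear on this: an 11-fold lower number from compound 1 to compound 2 (1.03 log units; beyond the scatter) and a 14-fold lower number from compound 1 to compound 3 (1.14 log units; beyond the scatter) show that only the bulky cyclohexyl brings a large change, while methyl and cyclobutyl sit together. Since trifluoromethyl adds few heavy atoms, the expected step is a 1.5-fold higher number from compound 3 to compound 4 (0.17 log units; within the scatter), that is, none beyond the scatter. Compound 4 is therefore estimated at 14 nM, within a range of 5 nM to 45 nM.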

Compound 4, inhibition constant: 13 nM
Compound 4: the middle estimate sits 1.1-fold (0.03 log units) above what was measured; measured number inside the range.
By their numbers in this assay, from the lowest: compounds 3, 2 and 4 (each within the scatter of the next); then compound 1.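

In this assay, trifluoromethyl falls in with methyl and cyclobutyl at this carbon: a 1.4-fold higher number from compound 3 to compound 4 (0.14 log units; within the scatter) and a 1.1-fold higher number from compound 2 to compound 4 (0.03 log units; within the scatter) leave the three unseparated. Only cyclohexyl stands apart, with a 10-fold lower number from compound 1 to compound 4 (1.00 log units; beyond the scatter) marking its distance, so exchanging the hydrogens of methyl for fluorine does not register here, just as the change from methyl to cyclobutyl did not. No measurement at hand explains this tolerance. Still open, on these data alone, is whether an amine or a carboxylic acid on this carbon would join the same group, and whether cyclopentyl would sit with cyclobutyl or with cyclohexyl.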